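A Nitrile-Bearing Aryl Group Exchanged: The Step to Compound 4

The source may hold more compounds than are shown below. What is called first, only, known or untested is meant among the compounds shown, and "the series" means these compounds.

For the measured compounds named here, in a functional assay on HepG2 cells (Homo sapiens) for cytotoxicity, read by MTT assay, with a stated time of 72 h (on this read-out lower numbers stand for stronger inhibition and higher numbers for weaker inhibition), three related compounds have numbers so far. Compound 1 (`N#Cc1ccc(/C=N/NC(=O)Nc2cc3c(Nc4ccc(F)c(Cl)c4)ncnc3cc2O[C@H]2CCOC2)cc1`) gives 26400 nM, compound 2 (`O=C(N/N=C/c1ccc(F)cc1Cl)Nc1cc2c(Nc3ccc(F)c(Cl)c3)ncnc2cc1O[C@H]1CCOC1`) gives 26100 nM, and compound 3 (`COc1cc2ncnc(Nc3ccc(F)c(Cl)c3)c2cc1NC(=O)N/N=C/c1ccc(C#N)cc1`) gives 34100 nM. Compound 3 thus stands within the scatter of both other compounds, and the three values cannot be ranked.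

Compound 4 (`COc1cc2ncnc(Nc3ccc(F)c(Cl)c3)c2cc1NC(=O)N/N=C/c1ccc(F)cc1Cl`) keeps the methyl group of compound 3 but carries 2-chloro-4-fluorophenyl in place of 4-cyanophenyl, on a carbon with a double bond to nitrogen: 2-chloro-4-fluorophenyl in place of 4-cyanophenyl on a carbon with a double bond to nitrogen.

The same exchange has been measured once, with oxolan-3-yl on the oxygen instead of methyl, and that step is a 1.0-fold lower number from compound 1 to compound 2 (0.00 log units; within the scatter). The exchange of oxolan-3-yl for methyl is a 1.3-fold higher number from compound 1 to compound 3 (0.11 log units; within the scatter). Both steps lie within the scatter, and compound 4 would complete the set of four. A single pair establishes no pattern, but it gives no reason to expect a real shift in either direction. The expected step is a 1.0-fold lower number from compound 3 to compound 4 (0.01 log units; within the scatter), which would be no change beyond the scatter. For compound 4, the estimated value in this assay is 33000 nM, with an expected range of 20000 nM to 52000 nM.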

Compound 4, half-maximal inhibitory concentration: 29200 nM
Compound 4: the middle estimate sits 1.1-fold (0.05 log units) above what was measured; low and high end bracket the measured number.
By their numbers in this assay, from the lowest: compounds 2, 1, 4 and 3 (each within the scatter of the next).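

The exchange of 4-cyanophenyl for 2-chloro-4-fluorophenyl, on a carbon with a double bond to nitrogen, now has a second reading in this assay, this time with methyl on the oxygen, as a 1.2-fold lower number from compound 3 to compound 4 (0.07 log units; within the scatter); the absence of a shift beyond the scatter is therefore no longer seen with oxolan-3-yl alone: the same change on two cores in this assay, a 1.0-fold lower number (0.00 log units; within the scatter) from compound 1 to compound 2 and a 1.2-fold lower number (0.07 log units; within the scatter) from compound 3 to compound 4, 1.2-fold (0.06 log units) apart, within the scatter of two such steps

The exchange of oxolan-3-yl for methyl also has a second reading, now with 2-chloro-4-fluorophenyl in place of 4-cyanophenyl, as a 1.1-fold higher number from compound 2 to compound 4 (0.05 log units; within the scatter): the same change on two cores in this assay, a 1.3-fold higher number (0.11 log units; within the scatter) from compound 1 to compound 3 and a 1.1-fold higher number (0.05 log units; within the scatter) from compound 2 to compound 4, 1.2-fold (0.06 log units) apart, within the scatter of two such steps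

The four compounds thus complete a set in which neither change moves the number beyond the scatter, whichever group stands at the other place.

All four values lie within the scatter of their neighbours, so these compounds do not show what, if anything, at either place would produce a real step. Going by these compounds, it remains open whether a carboxylic acid on the aromatic ring, or an amine or a longer chain on the oxygen in place of methyl, would change the number in this cell assay.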